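From Pyridin-2-yl to (Pyridin-2-yl)methyl on the Amide

The source may report more compounds than this note shows. Statements on the series, on what has been measured and on what is new or still open speak of the compounds shown alone.

Compound 1 `O=C(Cn1c(=O)oc2cc([N+](=O)[O-])ccc21)Nc1ccccn1`: 38.6% in an ADME assay on RAW264.7 cells (Mus musculus) for cytotoxicity, read by MTT assay, with a stated time of 72 h, tested at 50 uM; a higher number here means a stronger effect of the compound at the concentration tested, a lower number a weaker effect
Compound 2 `O=C(Cn1c(=O)oc2cc(Cl)ccc21)Nc1ccccn1`: 33% in this assay

Compound 1 holds the higher of the two numbers in this assay, and the step of a number 5.6 percentage points lower from compound 1 to compound 2 (within the scatter) lies within the scatter. Compound 3 `O=C(Cn1c(=O)oc2cc([N+](=O)[O-])ccc21)NCc1ccccn1` alters compound 1 elsewhere: (pyridin-2-yl)methyl in place of pyridin-2-yl on an amide-type nitrogen. For the measured compounds named here, the only measured step concerns a chloro in place of nitro on an aromatic carbon and says nothing about a change on the amide-type nitrogen, so no step beyond the scatter is expected in this assay. Compound 3 is therefore estimated at 38%, between 20% and 55%, an expected step of a number 0.6 percentage points lower from compound 1 to compound 3 (within the scatter).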

Compound 3, a percentage reported as inhibition, at one concentration (the size of the read-out at that concentration, not a potency): 21.8%
Compound 3: middle estimate off by 16.2 percentage points, on the high side; the range from low to high includes it.
By their numbers in this assay, from the lowest: compound 3; then compounds 2 and 1 (each within the scatter of the next).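

In this assay, the amide-type nitrogen proves to be a place where a small change can move the read-out beyond the scatter: (pyridin-2-yl)methyl in place of pyridin-2-yl gives a number 16.8 percentage points lower from compound 1 to compound 3 (beyond the scatter). Both groups carry the same pyridine ring, so the difference lies in how that ring is attached to the nitrogen. Nothing available explains the step.

As far as these compounds go, whether a longer chain, such as (pyridin-2-yl)ethyl, would give a further step remains open. So does whether the same change would give a similar step with the chloro group of compound 2.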